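Compound 4: an unsubstituted benzamide after compound 3

This account rests on a few compounds, and the source may have more. Where it says the series, first, only, none or still open, it means among the compounds named here.

Compound 1 `O=C(Nc1cccc(-n2cc(-c3ccncc3)c(-c3ccc(Cl)c(O)c3)n2)c1)Nc1cccc(C(F)(F)F)c1` gives 7650 nM in a functional assay on U-251 cells (Homo sapiens) for inhibition, read by sulforhodamine B assay, with a stated time of 48 h; on this read-out higher numbers stand for weaker inhibition of growth and lower numbers for stronger inhibition of growth. Compound 2 `COc1cc(-c2nn(-c3cccc(NC(=O)Nc4ccc(Cl)c(Cl)c4)c3)cc2-c2ccncc2)ccc1Cl` gives 2470 nM in this assay. Compound 3 `COc1cc(-c2nn(-c3cccc(NC(=O)c4ccc(Cl)c(C(F)(F)F)c4)c3)cc2-c2ccncc2)ccc1Cl` carries an amide where compound 2 carries a urea. In this assay compound 3 reaches only the limit of the assay, > 32500 nM, and no number. The step of an at least 13-fold higher number from compound 2 to compound 3 (1.11 log units; beyond the scatter) is the single measured step among these compounds, and it runs into (the limit of > 32500 nM in this assay, at which 1 of the 3 values shown sits), so only its least size is known. Compound 3 therefore stands at the limit, not at a number.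

Compound 4 `COc1cc(-c2nn(-c3cccc(NC(=O)c4ccccc4)c3)cc2-c2ccncc2)ccc1Cl` differs from compound 3 by phenyl in place of 4-chloro-3-(trifluoromethyl)phenyl on a carbonyl carbon. For the measured compounds named here, no measured step changes the aryl group on the carbonyl carbon; the one measured step alters the link from urea to amide, and it does not bear directly on this change. The expectation for compound 4 in this assay thus rests only on the limit shown by compound 3, > 32500 nM, and compound 4 is expected to stay weak, with the step of an at least 1.0-fold lower number from compound 3 to compound 4 (0.03 log units; that floor lies within the scatter) estimated as none beyond the scatter. The estimate for compound 4 in this assay is 30000 nM, within a range from 8000 nM to 100000 nM, with a fair chance that only a limit is reported again.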

Compound 4, concentration for total growth inhibition: 30800 nM
Compound 4: the middle estimate sits 1.0-fold (0.01 log units) below what was measured; the range from low to high includes it.
By their numbers in this assay, from the lowest: compound 2; then compound 1; then compound 4. At a limit, above all of these: compound 3.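

In this assay, the step of a 12-fold higher number from compound 2 to compound 4 (1.10 log units; beyond the scatter) gives the first full size for moving from a urea to an amide on this carbonyl carbon, where the earlier step gave only a least size, although here the change also replaces (3,4-dichlorophenyl)amino with a bare phenyl. The second step, an at least 1.0-fold lower number from compound 3 to compound 4 (0.02 log units; that floor lies within the scatter), shows no gain beyond the scatter from removing the chlorine and trifluoromethyl of the 4-chloro-3-(trifluoromethyl)phenyl group, so neither the substituted nor the bare aryl amide approaches compound 2 on the values shown. The true size of this second step cannot be read, because compound 3 has a limit and not a number: the limit of > 32500 nM in this assay, at which 1 of the 4 values shown sits.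

The compounds shown leave open how much of the loss belongs to the link itself and how much to the aryl group, a question that a urea carrying plain phenylamino on the carbonyl carbon would bear on. They also leave open whether an amine or a carboxylic acid on the phenyl of compound 4 would shift its growth inhibition at all.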